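This account rests on a few compounds, and the source may have more. Where it says the series, first, only, none or still open, it means among the compounds named here.

Values so far in a functional assay on HeLa cells (Homo sapiens) for antiproliferative activity, read by MTT assay, with a stated time of 48 h; a higher number here means a weaker inhibitor, a lower number a stronger inhibitor
- compound 1 `CCN(CC)CCn1c(N)c(-c2nc3ccccc3[nH]2)c2nc(C#N)c(C#N)nc21` gives 11600 nM
- compound 2 `CN(C)CCCCn1c(N)c(C#N)c2nc(C#N)c(C#N)nc21` gives > 50000 nM (a limit, not a number)
- compound 3 `CCN(CC)CCn1c(N)c(-c2nc3ccccc3n2C)c2nc(C#N)c(C#N)nc21` gives > 50000 nM (a limit, not a number)

Compound 3 stands at > 50000 nM in this assay and this is a limit, not a number. Compound 4 `CN(C)CCCCn1c(N)c(-c2nc3ccccc3n2C)c2nc(C#N)c(C#N)nc21` differs from it thus: 2-(dimethylamino)ethyl in place of diethylamino on a saturated chain carbon, two bonds along the chain from an aromatic nitrogen. Within the data shown here, the only measured step is an at least 4.3-fold higher number from compound 1 to compound 3 (0.63 log units; beyond the scatter) and it is methyl in place of hydrogen on an aromatic nitrogen, which compound 4 keeps. Among the measured compounds shown here, no measured step changes the chain. Compound 2 also carries 4-(dimethylamino)butyl and gives > 50000 nM as a limit. No step beyond the scatter is therefore expected in this assay and compound 4 should stay near that limit. The expected step is a number no higher from compound 3 to compound 4 (the limit leaves the size open) for now. For compound 4 the estimated value is 50000 nM within an expected range of 20000 nM to 100000 nM for this measurement.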

Compound 4, half-maximal inhibitory concentration: 460 nM
For compound 4 the middle estimate is 110-fold (2.04 log units) above the measured one; the measured number lies below the stated range.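

In this assay, the chain alone carries a large effect: 4-(dimethylamino)butyl in place of 2-(diethylamino)ethyl gives an at least 100-fold lower number from compound 3 to compound 4 (2.03 log units; beyond the scatter). That chain is not sufficient by itself, as 1-methyl-1H-benzimidazol-2-yl in place of cyano, with 4-(dimethylamino)butyl kept, gives an at least 100-fold lower number from compound 2 to compound 4 (2.03 log units; beyond the scatter). Both steps start from a limit, so their full size cannot be read: the limit of > 50000 nM in this assay, at which 2 of the 4 values shown sit.

Chain length and the amine end change together here, and a 4-(diethylamino)butyl or a 2-(dimethylamino)ethyl chain would separate them. From the compounds shown here alone, how a piperidine end would compare also remains open.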